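Dropping the nitro group from compound 2

This account rests on a few compounds, and the source may have more. Where it says the series, first, only, none or still open, it means among the compounds named here.

Measured so far:
compound 1 `CC1=NC(C)=C(C(=O)O)C(c2ccccc2[N+](=O)[O-])/C1=C(\O)OC/C=C/c1ccccc1` — 37000 nM
compound 2 `CC1=NC(C)=C(C(=O)O)C(c2ccc([N+](=O)[O-])cc2)/C1=C(\O)OC/C=C/c1ccccc1` — 21000 nM

Both compounds were tested in a functional assay on IMR-32 cells for inhibition of Voltage-dependent N-type calcium channel subunit alpha-1B (Homo sapiens), read by calcium flux; on this read-out lower numbers stand for stronger inhibition and higher numbers for weaker inhibition. Going by the values given here, compound 2 gives the lowest of the two numbers, but its only neighbour is compound 1, and the step of a 1.8-fold lower number from compound 1 to compound 2 (0.25 log units; within the scatter) lies within the scatter, so the two cannot be ranked against each other. The next compound, compound 3 `CC1=NC(C)=C(C(=O)O)C(c2ccccc2)/C1=C(\O)OC/C=C/c1ccccc1`, has not yet been measured. It differs from compound 2 by hydrogen in place of nitro on an aromatic carbon, which, cut one bond further out, reads 4-nitrophenyl to phenyl. Among the compounds with values here, no measured step removes a nitro group; the one step known only moves it, and that move stayed within the scatter. Compound 3 is therefore expected to sit in the same weak range as compound 2, with a step of a 1.4-fold higher number from compound 2 to compound 3 (0.15 log units; within the scatter) that may be no larger than the scatter. The estimate for compound 3 is 30000 nM, with a range from 10000 nM to 90000 nM.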

Compound 3, half-maximal inhibitory concentration: 2000 nM
Beside the measured number, compound 3's estimate is 15-fold (1.18 log units) above it; measured number below the stated range.
By their numbers in this assay, from the lowest: compound 3; then compounds 2 and 1 (each within the scatter of the next).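

In this assay, the presence of the nitro group matters far more than where it sits. Moving it from 2-nitrophenyl to 4-nitrophenyl gave only a step within the scatter, a 1.8-fold lower number from compound 1 to compound 2 (0.25 log units; within the scatter), whereas replacing it with hydrogen gives an 11-fold lower number from compound 2 to compound 3 (1.02 log units; beyond the scatter) and a 19-fold lower number from compound 1 to compound 3 (1.27 log units; beyond the scatter), so compound 3, with its plain phenyl, has the lowest number of the three whichever nitro compound it is set against. No measurement shown here explains why the number falls when the nitro group leaves. On these data alone, it remains open whether the loss of inhibition belongs to nitro itself or would follow any group on that aromatic carbon. A compound carrying an amine, a methoxy group or a fluorine atom there would help to separate those two readings.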